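Notes: methanesulfonamido in place of ethoxycarbonyl

The source may hold more compounds than are shown below. What is called first, only, known or untested is meant among the compounds shown, and "the series" means these compounds.

Measured in a functional assay for inhibition, with Homo sapiens as the target; on this read-out lower numbers stand for stronger inhibition and higher numbers for weaker inhibition:
- Compound 1 `CNC(=O)C(CC1CCCCC1)Nc1nc2cc(C)ccc2o1`: 72 nM
- Compound 2 `Cc1ccc2oc(NC(CC3CCCCC3)C3=CN(C)NO3)nc2c1`: 26 nM
- Compound 3 `CCOC(=O)c1ccc2oc(NC(CC3CCCCC3)c3ccccc3)nc2c1`: 45 nM

Compound 3, at 45 nM, lies within the scatter of both other compounds, so this assay does not separate it from compound 1 or from compound 2. Only those two are separated from each other.

The next compound to be read is compound 4 `CS(=O)(=O)Nc1ccc2oc(NC(CC3CCCCC3)c3ccccc3)nc2c1`, which has no value yet. Its difference from compound 3 is methanesulfonamido in place of ethoxycarbonyl on an aromatic carbon. In words, this is methanesulfonamido in place of ethoxycarbonyl on an aromatic carbon.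

Among the compounds with values here, no measured step covers a change at this place. Within the data shown here, the one measured step, a 2.8-fold lower number from compound 1 to compound 2 (0.44 log units; beyond the scatter), sits on a saturated chain carbon, not on the aromatic carbon changed here. It therefore gives a rough idea of size in this small series, but no direction. The group that enters matches the one that leaves in heavy-atom count, but differs in kind, so a wide range is needed and no step beyond the scatter can be predicted with confidence. The expected change is a 1.2-fold higher number from compound 3 to compound 4 (0.09 log units; within the scatter), an estimate that carries no firm direction.

For compound 4 the estimated value is 55 nM, with an expected range from 18 nM to 170 nM.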

Compound 4, half-maximal inhibitory concentration: 160 nM
For compound 4 the middle estimate is 2.9-fold (0.46 log units) below the measured one, and the stated range covers the measured number.
By their numbers in this assay, from the lowest: compounds 2, 3 and 1 (each within the scatter of the next, the first and the last beyond it); then compound 4.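

In this assay, methanesulfonamido in place of ethoxycarbonyl, on the aromatic carbon that is meta to a fused ring and para to a fused ring, gives a 3.6-fold higher number from compound 3 to compound 4 (0.55 log units; beyond the scatter). Within the data shown here, this is the first step read at this position, and it shows that the number here depends on the group carried, which the earlier compounds could not show. The two groups are equal in heavy-atom count and differ in their atoms and in the hydrogen-bond donor that methanesulfonamido brings, but no measurement on hand bears on what lies behind the step.

Going by these compounds, with only these two groups at this aromatic carbon, it stays open whether a carboxylic acid, an amine or a methyl there would read closer to compound 3 or to compound 4, and whether a methyl on the sulfonamide nitrogen, which removes the donor, would keep the higher number. Also open, on these data alone, is whether the same exchange would give a step of similar size on the core of compound 1 or compound 2.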